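The compounds below may be only part of what the source reports. "The series", "measured", "known", "first", "only" and "open" are said of these compounds alone.

Values in a physicochemical assay for solubility, in phosphate buffer, at pH 7.4 (a higher number here means a more soluble compound, a lower number a less soluble compound), for the measured compounds
Compound 1 (`CCNC(=O)Nc1nc2cc(-c3cccnc3)c(=O)n(C(C)C)c2s1`) gives 42000 nM
Compound 2 (`CCNC(=O)Nc1nc2cc(-c3cncnc3)c(=O)n(C(C)C)c2s1`) gives 7000 nM
Compound 3 (`CCNC(=O)Nc1nc2cc(-c3cncc(F)c3)c(=O)n(C(C)C)c2s1`) gives 73000 nM

Compound 3 has the highest of the three numbers, but it stands level with compound 1 within the scatter. Only compound 2 lies clearly apart from it, as a 10-fold higher number from compound 2 to compound 3 (1.02 log units; beyond the scatter) shows. The next compound, compound 4 (`CCNC(=O)Nc1nc2cc(-c3cncc(OC)c3)c(=O)n(C(C)C)c2s1`), carries methoxy in place of fluoro on an aromatic carbon, a change counted as methoxy in place of fluoro on an aromatic carbon here.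

Among the measured compounds shown here, no measured step exchanges these two groups. The nearest evidence is a 1.7-fold higher number from compound 1 to compound 3 (0.24 log units; within the scatter) for fluoro in place of hydrogen on an aromatic carbon. The other two steps are larger. One is a 6.0-fold lower number from compound 1 to compound 2 (0.78 log units; beyond the scatter). The other is a 10-fold higher number from compound 2 to compound 3 (1.02 log units; beyond the scatter). Both of these steps involve pyrimidin-5-yl, which neither compound 3 nor compound 4 contains, so they bear on this change only weakly.

A small step in this assay is therefore expected, leaning downward, since compound 3 tops a narrow set and compound 1 gives 42000 nM without the fluoro. The expected move is a 1.6-fold lower number from compound 3 to compound 4 (0.21 log units; within the scatter) and no more. For compound 4 the estimate is 45000 nM with an expected range from 15000 nM to 100000 nM in this reading.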

Compound 4, solubility: < 5000 nM
Compound 4: a limit, no number; the forecaster's own chance of this, stated with the estimate: 10%; middle value at least 9.0-fold (0.95 log units) away from the limit.
By their numbers in this assay, from the lowest: compound 2; then compounds 1 and 3 (each within the scatter of the next). At a limit, below all of these: compound 4.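

In this assay, among the compounds shown here, the position two atoms from the ring nitrogen had so far looked tolerant, with hydrogen and fluoro there lying within the scatter of each other, but methoxy gives an at least 14-fold lower number from compound 3 to compound 4 (1.16 log units; beyond the scatter) and an at least 8.4-fold lower number from compound 1 to compound 4 (0.92 log units; beyond the scatter). So the exchange of fluoro for methoxy, which adds a heavy atom and a hydrogen-bond acceptor, is the first change at this position to separate compounds clearly, and these steps are floors, not exact sizes. Compound 4 gives a limit and no number, so its place in the series is fixed only from one side: the limit of < 5000 nM in this assay, at which 1 of the 4 values shown sits. Against the pyrimidin-5-yl compound the reading is weaker, with an at least 1.4-fold lower number from compound 2 to compound 4 (0.14 log units; that floor lies within the scatter), so the order of those two compounds remains unsettled.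

From the compounds shown here alone, how far compound 4 lies past its limit remains open, and with it the true size of all three steps. The compounds shown also do not tell whether this drop is particular to methoxy or would also come with an amine, a nitrile or a longer chain such as ethoxy at the same position.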